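A methyl-to-fluoro swap at micromolar cytotoxicity

This account rests on a few compounds, and the source may have more. Where it says the series, first, only, none or still open, it means among the compounds named here.

Compound 1 `O=C1OC[C@H](Cc2ccccc2)[C@H]1Cc1ccc(Cl)c(Cl)c1`: 19000 nM
Compound 2 `Cc1ccccc1C[C@H]1COC(=O)[C@@H]1Cc1ccc(Cl)c(Cl)c1`: 22000 nM

Both numbers come from a functional assay on HL-60 cells (Homo sapiens) for cytotoxicity, read by WST assay, with a stated time of 48 h; on this read-out lower numbers stand for an effect already at smaller amounts and higher numbers for an effect only at larger amounts of compound. Only these two compounds have been measured so far, and compound 2 stands level with compound 1, within the usual scatter. The next compound, compound 3 `O=C1OC[C@H](Cc2ccccc2F)[C@H]1Cc1ccc(Cl)c(Cl)c1`, differs from compound 2 in one place: fluoro in place of methyl on an aromatic carbon. In words, this is fluoro in place of methyl on an aromatic carbon, ortho to a large group.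

Among the measured compounds shown here, the one measured step that bears on this is a 1.2-fold higher number from compound 1 to compound 2 (0.06 log units; within the scatter), where methyl took the place of hydrogen on an aromatic carbon. For the measured compounds named here, no fluoro compound has been measured, so this evidence is thin. A shift beyond the scatter is therefore not expected in this assay. The expected step is a 1.1-fold lower number from compound 2 to compound 3 (0.04 log units; within the scatter). For compound 3 the estimated value is 20000 nM, with an expected range from 10000 nM to 40000 nM.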

Compound 3, half-maximal effective concentration: 28000 nM
Beside the measured number, compound 3's estimate is 1.4-fold (0.15 log units) below it; measured number inside the range.
By their numbers in this assay, from the lowest: compounds 1, 2 and 3 (each within the scatter of the next).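

In this assay, fluoro in place of methyl gives a 1.3-fold higher number from compound 2 to compound 3 (0.10 log units; within the scatter) and fluoro in place of hydrogen gives a 1.5-fold higher number from compound 1 to compound 3 (0.17 log units; within the scatter). This place on the aromatic ring, ortho to a large group, has now carried hydrogen, methyl and fluoro, and all three compounds stand level within the usual scatter, so a third kind of atom at this spot leaves the cytotoxicity reading where it was, whereas before only hydrogen and methyl could be compared. Nothing available explains why the reading stays level across these three compounds.

On these data alone, whether an amine, a carboxylic acid or a methoxy group at this place would move the number beyond the scatter remains open. Also open, as far as these compounds go, is whether fluoro would behave the same way at another place on this ring.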